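Trifluoromethoxy for trifluoromethyl in two hydroxyamide series

The compounds below may be only part of what the source reports. "The series", "measured", "known", "first", "only" and "open" are said of these compounds alone.

Measured so far in a functional assay on LNCaP cells (Homo sapiens) for antiproliferative activity, read by propidium iodide staining, with a stated time of 96 h; a higher number here means a weaker inhibitor, a lower number a stronger inhibitor:
compound 1 `CC(O)(CSc1ccc(C(F)(F)F)cc1)C(=O)Nc1cccc(S(F)(F)(F)(F)F)c1`: 17500 nM
compound 2 `CC(O)(CSc1ccc(OC(F)(F)F)cc1)C(=O)Nc1cccc(S(F)(F)(F)(F)F)c1`: 10300 nM
compound 3 `CC(O)(COc1cccc(C(F)(F)F)c1)C(=O)Nc1cccc(S(F)(F)(F)(F)F)c1`: 28800 nM

Compound 1 and compound 2 differ in one place only, (trifluoromethoxy in place of trifluoromethyl on an aromatic carbon), and the step between them is a 1.7-fold lower number from compound 1 to compound 2 (0.23 log units; within the scatter). Compound 3 is built on a different core from compound 1; the difference between the two cores is not broken down here. Against compound 2 the gap is larger: compound 2 gives 10300 nM where compound 3 gives 28800 nM, a gap beyond the scatter.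

Compound 4 `CC(O)(COc1cccc(OC(F)(F)F)c1)C(=O)Nc1cccc(S(F)(F)(F)(F)F)c1` is not yet measured. It stands to compound 3 as compound 2 stands to compound 1: trifluoromethoxy in place of trifluoromethyl on an aromatic carbon. Within the data shown here, this is the same kind of change as the one from compound 1 to compound 2, not the same change, since the place differs: there the group sits para to a large group, here meta to a large group.

Among the measured compounds shown here, the step from compound 3 to compound 4 is expected to be a 1.6-fold lower number from compound 3 to compound 4 (0.20 log units; within the scatter), of about the same size as the earlier one, because a 1.7-fold lower number from compound 1 to compound 2 (0.23 log units; within the scatter) is the only guide to this kind of change on hand; whether the changed place matters is unknown. Compound 4 is accordingly estimated at 18000 nM in this assay, with a likely range from 9000 nM to 36000 nM.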

Compound 4, half-maximal inhibitory concentration: 15200 nM
Beside the measured number, compound 4's estimate is 1.2-fold (0.07 log units) above it, within the range that was stated.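

In this assay, trifluoromethoxy in place of trifluoromethyl on the core of compound 3 gives a 1.9-fold lower number from compound 3 to compound 4 (0.28 log units; within the scatter). Set beside the same exchange on the core of compound 1, the step is of matching size on both cores: the same change on two cores in this assay, a 1.7-fold lower number (0.23 log units; within the scatter) from compound 1 to compound 2 and a 1.9-fold lower number (0.28 log units; within the scatter) from compound 3 to compound 4, 1.1-fold (0.05 log units) apart, within the scatter of two such steps. Among these compounds, the change therefore carries from one core to the other here with no detectable difference in its size, but neither step alone lies beyond the scatter, so this does not show that trifluoromethoxy truly outperforms trifluoromethyl on either core, and with only two pairs, in which the group also sits at different places, it cannot show how far the agreement extends or whether place matters.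

The compounds shown leave open whether a nitrile or a carboxylic acid at the same aromatic carbon would follow trifluoromethoxy and trifluoromethyl or depart from them on either core. All four compounds also carry the same pentafluorosulfanyl group on the amide side, so whether the step holds with a nitrile or an amine in its place remains an open question for the series.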